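This account rests on a few compounds, and the source may have more. Where it says the series, first, only, none or still open, it means among the compounds named here.

Working notes on the series. Among the measured compounds shown here, compound 2 `CCN(CC)CCn1cnnc1-c1cc(Oc2ccc(NC(=O)Nc3ccc(F)c(F)c3)cc2F)ccn1` gives 7.1% in an assay on isolated protein for inhibition of proto-oncogene tyrosine-protein kinase receptor Ret (Homo sapiens), read by mobility shift assay, with a stated time of 1 h, tested at 10 uM (on this read-out higher numbers stand for more inhibition at the one concentration tested (going by the name of the read-out) and lower numbers for less inhibition), the higher of the two numbers so far; the nearest is compound 3 `CCN(CC)CCn1cnnc1-c1cc(Oc2ccc(NC(=O)Nc3ccc(F)c(Cl)c3)cc2F)ccn1`, which gives 1.9% in this assay, and the step of a number 5.2 percentage points lower from compound 2 to compound 3 (within the scatter) lies within the scatter. Compound 1 `CCN(CC)CCn1cnnc1-c1cc(Oc2ccc(NC(=O)Nc3ccccc3C(F)(F)F)cc2F)ccn1` has "not determined" (no result reported) in this assay, so no number is available for it.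

The step now followed leads to compound 4 `CN(C)CCCn1cnnc1-c1cc(Oc2ccc(NC(=O)Nc3ccc(F)c(F)c3)cc2F)ccn1`, not yet measured in this assay. The change is (dimethylamino)methyl in place of diethylamino on a saturated chain carbon, two bonds along the chain from an aromatic nitrogen. For the measured compounds named here, the only measured step, chloro in place of fluoro on an aromatic carbon, sits on a different part of the molecule and was within the scatter, so it does not speak directly to a change on the saturated chain. Going by the values given here, nothing measured here separates a diethylamino from a (dimethylamino)methyl on this chain, and both numbers measured so far are small and close to each other. The expected step of a number 0.1 percentage points lower from compound 2 to compound 4 (within the scatter) is therefore one of no size beyond the scatter. Compound 4 is estimated at 7% in this assay, with a range from 0% to 18%, low values being the more likely given what compound 2 and compound 3 show.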

Compound 4, a percentage reported as inhibition, at one concentration (the size of the read-out at that concentration, not a potency): 30.9%
Estimate against measurement, compound 4: 23.9 percentage points below; measured number above the stated range.
By their numbers in this assay, from the lowest: compounds 3 and 2 (each within the scatter of the next); then compound 4.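

Among the compounds shown here, on a saturated chain carbon, two bonds along the chain from an aromatic nitrogen, (dimethylamino)methyl in place of diethylamino gives a number 23.8 percentage points higher from compound 2 to compound 4 (beyond the scatter) in this assay and is the only step beyond the scatter; the step of a number 5.2 percentage points lower from compound 2 to compound 3 (within the scatter) on an aromatic carbon did not show that the read-out could move at all. Cut one bond further out, the same change reads 2-(diethylamino)ethyl to 3-(dimethylamino)propyl, so the chain and the groups on the amine nitrogen differ together and this single step cannot assign the rise to either. No measurement available here bears on the reason for this rise.

The compounds shown leave open whether the rise follows the propyl chain or the methyl groups on the amine, which a 2-(dimethylamino)ethyl or a 3-(diethylamino)propyl chain on the same core would separate. Also open, from the compounds shown here alone, is whether a ring amine such as pyrrolidine or morpholine at the end of the chain would give a number like that of compound 4 at 30.9% in this assay or one nearer the two lower compounds.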